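The compounds below may be only part of what the source reports. "The series", "measured", "known", "first", "only" and "open" are said of these compounds alone.

Within the data shown here, in a functional assay on MCF7 cells (Homo sapiens) for antiproliferative activity, read by MTT assay, with a stated time of 72 h (on this read-out higher numbers stand for weaker inhibition and lower numbers for stronger inhibition), compound 3 `N#Cc1ccc(-c2csc(N3N=C(c4ccc(N5CCCCC5)cc4)CC3c3ccc(Cl)cc3)n2)cc1` gives 9760 nM, the only number among the three measured compounds. Compound 1 `O=[N+]([O-])c1ccc(-c2csc(N3N=C(c4ccc(N5CCCCC5)cc4)CC3c3ccc(Cl)cc3)n2)cc1` returns > 100000 nM, a limit and not a number. Compound 2 `Clc1ccc(C2CC(c3ccc(N4CCCCC4)cc3)=NN2c2nc(-c3ccc(Br)cc3)cs2)cc1` likewise returns > 100000 nM, also a limit. Compound 4 `FC(F)(F)c1ccc(-c2csc(N3N=C(c4ccc(N5CCCCC5)cc4)CC3c3ccc(Cl)cc3)n2)cc1` differs from compound 3 by trifluoromethyl in place of cyano on an aromatic carbon. Among the measured compounds shown here, two measured steps bear on this change: an at least 10-fold lower number from compound 1 to compound 3 (1.01 log units; beyond the scatter) and an at least 10-fold lower number from compound 2 to compound 3 (1.01 log units; beyond the scatter), both of them steps that install the cyano group, whereas a step that the two limits leave unreadable from compound 1 to compound 2. Taking the cyano group away again is therefore expected to raise the number in this assay, with the limit of > 100000 nM in this assay, at which 2 of the 3 values shown sit, a likely outcome. For compound 4 the estimate is 60000 nM, ranging from 15000 nM to 200000 nM, an expected step of a 6.1-fold higher number from compound 3 to compound 4 (0.79 log units; beyond the scatter).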

Compound 4, half-maximal inhibitory concentration: 23700 nM
Beside the measured number, compound 4's estimate is 2.5-fold (0.40 log units) above it; the measured number falls inside the stated range.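

In this assay, this position keeps a readable number with a second group, so the cyano group is not the only one that allows it, although the exchange gives a 2.4-fold higher number from compound 3 to compound 4 (0.39 log units; beyond the scatter). Trifluoromethyl also separates clearly from the bromo and nitro groups, with an at least 4.2-fold lower number from compound 2 to compound 4 (0.62 log units; beyond the scatter) and an at least 4.2-fold lower number from compound 1 to compound 4 (0.62 log units; beyond the scatter). Compound 4 thus stays off the limit that the bromo and nitro compounds share: the limit of > 100000 nM in this assay, at which 2 of the 4 values shown sit.

As far as these compounds go, whether an amine or a carboxylic acid at this position would give a readable number remains open. Also open, from the compounds shown here alone, is whether cyano would still give a lower number than trifluoromethyl on a different core.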